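Replacing a carbamate chain on an aziridinyl quinone core

This account rests on a few compounds, and the source may have more. Where it says the series, first, only, none or still open, it means among the compounds named here.

Compound 1, `CC1=C(N2CC2)C(=O)C(CCCOC(N)=O)=C(N2CC2)C1=O`, is one of three quinones measured in a functional assay on L1210 cells (Mus musculus), with a stated time of 12 days; a higher number here means a more potent compound, by a factor of ten per unit of this negative logarithm, a lower number a less potent compound. Compound 1 gives 5.93, the highest of the three numbers. Compound 3, `CCC(COC(N)=O)C1=C(N2CC2)C(=O)C(C)=C(N2CC2)C1=O`, gives 5.66 in this assay, which lies within the scatter of the number for compound 1. Compound 2, `CCC1=C(N2CC2)C(=O)C(CCOC(N)=O)=C(N2CC2)C1=O`, gives 5.48 in this assay, and its gap to compound 1 is beyond the scatter, so of these three only compound 2 is clearly weaker than compound 1.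

Compound 4, `COC(CO)C1=C(N2CC2)C(=O)C(C)=C(N2CC2)C1=O`, has not been measured. It differs from compound 1 in one place: a group of 5 heavy atoms (3 carbon, 2 oxygen; no ring) in place of a group of 7 heavy atoms (4 carbon, 1 nitrogen, 2 oxygen; no ring), on a double-bonded ring carbon. The group that leaves carries a carbamate, the group that enters a free hydroxyl and a methoxy.

Among the compounds with values here, no measured pair shows exactly this change. The three numbers on hand lie close together, and compound 3, which also bears a methyl on the core, sits close to compound 1. A modest downward step is expected; the estimated step of a number 0.43 log units lower from compound 1 to compound 4 (beyond the scatter) is small and near the edge of the scatter. Compound 4 is therefore expected to give about 5.5 in this assay, with a likely range from 5 to 6.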

Compound 4, logarithm of the reciprocal of the active concentration, log(1/C): 5.75
Estimate against measurement, compound 4: 0.25 log units below, and the stated range covers the measured number.
By their numbers in this assay, from the lowest: compounds 2, 3, 4 and 1 (each within the scatter of the next, the first and the last beyond it).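

In this assay, replacing the carbamate-bearing chain with 2-hydroxy-1-methoxyethyl gives a number 0.18 log units lower from compound 1 to compound 4 (within the scatter). All three earlier compounds carry a carbamate, so they could not show whether this position needs one; compound 4 shows that, on this core, a chain without a carbamate but with a free hydroxyl and a methoxy can stand here with no change beyond the scatter. Nothing available explains why this exchange leaves the number within the scatter.

Within the data shown here, the single step does not separate what the free hydroxyl and the methoxy each contribute, since both enter together with the loss of the carbamate. It also leaves open how a primary amine or a carboxylic acid in place of that hydroxyl would read in this assay.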